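A few compounds are considered here, and "the series" means these few. Any claim that something is new, unique, unknown or untested is made for them only; others in the source may bear on it.

Working notes on the series. Three compounds share one core and have been run in a physicochemical assay for lipophilicity, read by HPLC, tested at 5 mM; on this read-out lower numbers stand for lower lipophilicity and higher numbers for higher lipophilicity. Compound 1 `CC(Oc1ccc(Oc2ccc(F)cc2)cc1)C(=O)Cn1nnc(-c2ccccc2)n1` gives 5.3; compound 2 `CC(Oc1ccc(Oc2ccc(Cl)cc2)cc1)C(=O)Cn1nnc(-c2ccccc2)n1` gives 6; compound 3 `CC(Oc1ccc(-c2ccccc2)cc1)C(=O)Cn1nnc(-c2ccccc2)n1` gives 5.3. The steps between them are a number 0.70 log units higher from compound 1 to compound 2 (beyond the scatter), no change at the digits printed from compound 1 to compound 3 (within the scatter) and a number 0.70 log units lower from compound 2 to compound 3 (beyond the scatter). Compound 3 therefore stands level with compound 1, the two together the lowest of the three numbers, with compound 2 the furthest away.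

The next member, compound 4 `COC(=O)c1ccc(-c2nnn(CC(=O)C(C)Oc3ccc(-c4ccccc4)cc3)n2)cc1`, differs from compound 3 in one place: methoxycarbonyl in place of hydrogen on an aromatic carbon. Among the measured compounds shown here, none of the three measured steps touches this part of the molecule; each of them concerns the substituent on the other side of the core, so no measured step bears directly on the change from compound 3 to compound 4. The measured steps only show that a change of one small group on an aromatic ring in this series can move this assay by a modest amount or not at all. With nothing closer to go on, the expected step is a number 0.10 log units lower from compound 3 to compound 4 (within the scatter), a change not expected to go beyond the scatter. In this assay compound 4 is estimated at 5.2, within a range from 4.7 to 5.7.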

Compound 4, partition coefficient: 5.4
For compound 4 the middle estimate is 0.20 log units below the measured one; the measured number falls inside the stated range.
By their numbers in this assay, from the lowest: compounds 1, 3 and 4 (each within the scatter of the next); then compound 2.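

Methoxycarbonyl in place of hydrogen on an aromatic carbon, para to a large group, comes with a number 0.10 log units higher from compound 3 to compound 4 (within the scatter) in this assay and gives the first reading at this position. The earlier steps shown here all concerned another part of the molecule, whereas this one shows that, for this single pair, phenyl to 4-(methoxycarbonyl)phenyl adds 4 heavy atoms (2 carbon, 2 oxygen) and 2 hydrogen-bond acceptors without a step beyond the scatter. No measurement at hand accounts for this outcome.

From the compounds shown here alone, a single group at this place sets no trend, and it remains open whether a carboxylic acid, an amine or a longer chain on the same aromatic carbon would also stay within the scatter of compound 3. Going by these compounds, it is also open whether methoxycarbonyl at this place would give a similar step with the 4-chlorophenoxy group of compound 2 in place of the phenyl of compound 3.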